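The source may hold more compounds than are shown below. What is called first, only, known or untested is meant among the compounds shown, and "the series" means these compounds.

Measured compounds:
- compound 1 `Cc1ccc(CNC(=O)c2nn(-c3ccc(F)cc3)c(CC[C@@H](O)C[C@@H](O)CC(=O)O)c2C(C)C)cc1`, 2.5 nM in an assay on microsomes from liver for inhibition of 3-hydroxy-3-methylglutaryl-coenzyme A reductase (Rattus norvegicus); a higher number here means a weaker inhibitor, a lower number a stronger inhibitor
- compound 2 `CC(C)c1c(C(=O)NCc2cccc(F)c2F)nn(-c2ccc(F)cc2)c1OC[C@@H](O)C[C@@H](O)CC(=O)O`, 2 nM in this assay
- compound 3 `CC(C)c1c(C(=O)N2CCC[C@H](N3CCC4C=CC=CC4C3)C2)nn(-c2ccc(F)cc2)c1CC[C@@H](O)C[C@@H](O)CC(=O)O`, 10 nM in this assay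

Compound 2 has the lowest number of the three. Its gap to compound 1 lies within the usual scatter, so these two cannot be told apart; its gap to compound 3 lies beyond the scatter, so compound 2 is the stronger inhibitor of that pair.

Compound 4 `CC(C)c1c(C(=O)N2CCCCC2)nn(-c2ccc(F)cc2)c1OC[C@@H](O)C[C@@H](O)CC(=O)O` has not yet been measured. It differs from compound 2 in one place: piperidin-1-yl in place of (2,3-difluorobenzyl)amino on a carbonyl carbon. The amide thereby loses its only hydrogen-bond donor and the aromatic ring with its two fluorines.

Going by the values given here, no measured pair shows exactly this change, so the expected step rests on the spread of the three numbers. Because compound 3 gives 10 nM, a move away from compound 2 toward a higher number is expected for compound 4, that is a 7.5-fold higher number from compound 2 to compound 4 (0.88 log units; beyond the scatter). Compound 4 is therefore estimated at 15 nM, with a likely range from 5 nM to 50 nM.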

Compound 4, half-maximal inhibitory concentration: 47 nM
Beside the measured number, compound 4's estimate is 3.1-fold (0.50 log units) below it; low and high end bracket the measured number.
By their numbers in this assay, from the lowest: compounds 2 and 1 (each within the scatter of the next); then compound 3; then compound 4.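

In this assay, piperidin-1-yl in place of (2,3-difluorobenzyl)amino on the carbonyl carbon gives a 24-fold higher number from compound 2 to compound 4 (1.37 log units; beyond the scatter), the first change among these compounds that can be read in one place alone. It shows that the group on this carbonyl carbon strongly affects the measured inhibition, and that piperidin-1-yl does not keep the low number of compound 2. Nothing available explains the size of this step.

This single step removes the amide hydrogen and the aromatic ring with its two fluorines together, and it cannot show which of these losses matters. Benzylamino without fluorine would test the fluorines, while N-methylbenzylamino would keep the aromatic ring but lack the amide hydrogen.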